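This account rests on a few compounds, and the source may have more. Where it says the series, first, only, none or still open, it means among the compounds named here.

Compound 3 `COc1cccc(OC)c1OCCNCCOc1ccccc1OCc1cccc([N+](=O)[O-])c1` carries a 3-nitrobenzyl group on the shared core and, in an assay on CHO cells for displacement of a labelled ligand from Alpha-1B adrenergic receptor (Homo sapiens) (on this read-out lower numbers stand for stronger inhibition and higher numbers for weaker inhibition), compound 3 gives 0.794 nM. That is the highest number among the three compounds with a known value, though the gap to compound 1 `COc1cccc(OC)c1OCCNCCOc1ccccc1OCc1ccccc1Cl`, which in this assay gives 0.562 nM, is small: a 1.4-fold higher number from compound 1 to compound 3 (0.15 log units; within the scatter). The gap to compound 2 `COc1cccc(OC)c1OCCNCCOc1ccccc1OCc1ccc(C)cc1`, which gives 0.251 nM, is larger: a 3.2-fold higher number from compound 2 to compound 3 (0.50 log units; beyond the scatter). Between the two others the step is a 2.2-fold lower number from compound 1 to compound 2 (0.35 log units; beyond the scatter).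

Compound 4 `COc1cccc(COc2ccccc2OCCNCCOc2c(OC)cccc2OC)c1` arises from compound 3 by a single exchange: methoxy in place of nitro on an aromatic carbon. Among the measured compounds shown here, no measured pair shows exactly this exchange, but both measured steps into compound 3 are informative, because the move from a 4-methyl or 2-chloro substituent to 3-nitro raised the number, modestly or within the scatter. Removing the nitro in favour of methoxy is therefore expected to lower the number somewhat, and the expected step is a 1.8-fold lower number from compound 3 to compound 4 (0.25 log units; within the scatter). Compound 4 is accordingly estimated at 0.45 nM, with a range from 0.2 nM to 1 nM.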

Compound 4, inhibition constant: 2 nM
Estimate against measurement, compound 4: 4.4-fold (0.65 log units) below, and the stated range ends below it.
By their numbers in this assay, from the lowest: compound 2; then compounds 1 and 3 (each within the scatter of the next); then compound 4.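

In this assay, methoxy in place of nitro on this aromatic carbon gives a 2.5-fold higher number from compound 3 to compound 4 (0.40 log units; beyond the scatter) and thus shows that the 3-nitrobenzyl group is not the least favourable of the benzyl groups here, as the first three compounds alone might have suggested. Compound 4 now has the highest number of the four, with an 8.0-fold higher number from compound 2 to compound 4 (0.90 log units; beyond the scatter) and a 3.6-fold higher number from compound 1 to compound 4 (0.55 log units; beyond the scatter) both beyond the scatter, so the 3-methoxybenzyl group is the weakest of this set in this assay. Nothing in the available data accounts for this rise.

Still open, from the compounds shown here alone, is how a hydroxyl, an amine or a carboxylic acid on the same aromatic carbon would read in this assay against nitro and methoxy. Also open, going by these compounds, is whether methoxy on another carbon of that ring would give a similar number, since the steps from compound 1 and compound 2 change both the group and its place.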